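Removing the acetyl from compound 1

This account rests on a few compounds, and the source may have more. Where it says the series, first, only, none or still open, it means among the compounds named here.

In a functional assay on Huh-5-2 cells (Homo sapiens) for cytotoxicity, read by microscopy (on this read-out lower numbers stand for higher toxicity in this test and higher numbers for lower toxicity in this test), compound 1 (`CC(=O)OC[C@H]1O[C@@H](n2c(SCc3cc4ccccc4oc3=O)nc3cncnc32)[C@H](O)[C@@H]1O`) gives 8700 nM, compound 2 (`CC(=O)OC[C@H]1O[C@@H](n2c(SCc3cc4cc(Br)ccc4oc3=O)nc3cncnc32)[C@H](O)[C@@H]1O`) gives 31000 nM and compound 3 (`CC(=O)OC[C@H]1O[C@@H](n2c(SCc3cc4cc(C)ccc4oc3=O)nc3cncnc32)[C@H](O)[C@@H]1O`) gives 16000 nM. Compound 1 thus stands at the low end, together with compound 3: bromo in place of hydrogen on an aromatic carbon gave a 3.6-fold higher number from compound 1 to compound 2 (0.55 log units; beyond the scatter), while methyl there gave a 1.8-fold higher number from compound 1 to compound 3 (0.26 log units; within the scatter).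

Compound 4 (`O=c1oc2ccccc2cc1CSc1nc2cncnc2n1[C@@H]1O[C@H](CO)[C@@H](O)[C@H]1O`) differs elsewhere: hydrogen in place of acetyl on an oxygen on a saturated carbon. This turns acetoxymethyl into hydroxymethyl. Among the compounds with values here, no measured step touches this place, so those steps offer only a rough size. With compound 1 at 8700 nM, a small move toward a higher number seems likeliest, though the direction is uncertain. The expected change is a 1.6-fold higher number from compound 1 to compound 4 (0.21 log units; within the scatter). In this assay, the estimate for compound 4 is 14000 nM, with an expected range from 5000 nM to 45000 nM.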

Compound 4, half-maximal cytotoxic concentration: 50000 nM
For compound 4 the middle estimate is 3.6-fold (0.55 log units) below the measured one; the measured number lies above the stated range.
By their numbers in this assay, from the lowest: compounds 1, 3, 2 and 4 (each within the scatter of the next, the first and the last beyond it).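

The earlier compounds shown here varied only an aromatic carbon, whereas this step shows that the oxygen on a saturated carbon also matters in this assay. Hydrogen in place of acetyl there gives a 5.7-fold higher number from compound 1 to compound 4 (0.76 log units; beyond the scatter), which means lower toxicity in this test. Nothing measured here explains this shift.

On these data alone, it remains open whether compound 2 and compound 3 would respond in the same way to losing the acetyl. Also open, as far as these compounds go, is what a longer acyl group, such as butyryl, or a benzoyl group would give in place of acetyl.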